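Fluoro in place of tert-butyl: expected cytotoxicity outcome

This account rests on a few compounds, and the source may have more. Where it says the series, first, only, none or still open, it means among the compounds named here.

Compound 1 `Cc1cc(NC(=O)Nc2ccccc2C(C)(C)C)c2ccccc2n1` was tested in an ADME assay on HEK293 cells (Homo sapiens) for cytotoxicity, with a stated time of 72 h; a higher number here means that more compound is needed for the effect, a lower number that less compound is needed. In this assay compound 1 reports only a limit, > 25000 nM, rather than a number. A second compound, compound 2 `Cc1cc(NC(=O)Nc2cccc(OC(F)(F)F)c2)c2ccccc2n1`, gives 22000 nM in this assay. The change from compound 1 to compound 3 `Cc1cc(NC(=O)Nc2ccccc2F)c2ccccc2n1` is fluoro in place of tert-butyl on an aromatic carbon. Within the data shown here, with no measured step to draw on, the expected step is a number no higher from compound 1 to compound 3 (the limit leaves the size open), which is no change beyond the usual scatter in either direction. Compound 3 is estimated at 25000 nM in this assay, with a range from 10000 nM to 60000 nM. A limit rather than a number seems likely again, as with compound 1 at the limit of > 25000 nM in this assay, at which 1 of the 2 values shown sits.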

Compound 3, half-maximal effective concentration: > 25000 nM
Compound 3 ended at the assay's limit; the forecaster's own chance of this, stated with the estimate: 60%; the middle value lies on the limit itself.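

In this assay, among these compounds, compound 1 and compound 3 each report only a limit, not a number, so no step between them can be read: the limit of > 25000 nM in this assay, at which 2 of the 3 values shown sit. On these data alone, whether fluoro in place of tert-butyl changes cytotoxicity at all remains open.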